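Swapping chloro for ethyl on the pyridine of compound 3

The source may hold more compounds than are shown below. What is called first, only, known or untested is meant among the compounds shown, and "the series" means these compounds.

Compound 3 `CC(C)c1ccc(NC(=O)N2CCN(c3ncccc3Cl)CC2)cc1` gives the lowest number of the three compounds measured in a functional assay on HEK293 cells for antagonist activity at transient receptor potential cation channel subfamily V member 1 (Rattus norvegicus) (a higher number here means a weaker inhibitor, a lower number a stronger inhibitor), at 17.3 nM. Compound 1 `CC(C)(C)c1ccc(NC(=O)N2CCN(c3ncccc3C(F)(F)F)CC2)cc1` gives 57.7 nM and compound 2 `O=C(Nc1ccc(Oc2ccccc2)cc1)N1CCN(c2ncccc2C(F)(F)F)CC1` gives 916 nM. Among the measured compounds shown here, the only single-point step among them, a 16-fold higher number from compound 1 to compound 2 (1.20 log units; beyond the scatter), concerns the other aromatic ring and does not touch the change considered here. Compound 4 `CCc1cccnc1N1CCN(C(=O)Nc2ccc(C(C)C)cc2)CC1` differs from compound 3 in one place: ethyl in place of chloro on an aromatic carbon, a small group replaced by another small group two atoms from the ring nitrogen. For the measured compounds named here, no measured pair speaks to this exchange, so the expected step of a 1.4-fold higher number from compound 3 to compound 4 (0.16 log units; within the scatter) is modest and uncertain in direction. Compound 4 is therefore estimated at 25 nM, with a range from 8 nM to 80 nM.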

Compound 4, half-maximal inhibitory concentration: 828 nM
Compound 4: middle estimate off by 33-fold (1.52 log units), on the low side, and the stated range ends below it.
By their numbers in this assay, from the lowest: compound 3; then compound 1; then compounds 4 and 2 (each within the scatter of the next).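

On the pyridine, at the carbon two atoms from the ring nitrogen, replacing chloro with ethyl is far from a neutral exchange of small groups. In this assay it gives a large step (a 48-fold higher number from compound 3 to compound 4 (1.68 log units; beyond the scatter)). This shows that the group at this position, and not only the group on the other aromatic ring, can strongly change the number, though no measured evidence here explains the step.

From the compounds shown here alone, how methyl, methoxy or an amine at this position would compare with chloro and ethyl remains open. Compound 1 and compound 3 carry trifluoromethyl and chloro here but also differ on the other aromatic ring, which leaves those two groups uncompared.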